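Notes on varying the amide end of the series

This account rests on a few compounds, and the source may have more. Where it says the series, first, only, none or still open, it means among the compounds named here.

Compound 2 `CC(=O)Nc1cccc(NC(=O)COc2ccc3c(=O)ccoc3c2)c1` gives the lowest of the two numbers seen so far: in an assay on isolated protein for inhibition of Rho-associated protein kinase 2 (Homo sapiens), read by scintillation counting, radiometric assay and 33P incorporation, with a stated time of 40 min, in the presence of a further agent that is not named here (on this read-out higher numbers stand for weaker inhibition and lower numbers for stronger inhibition), compound 2 gives 136 nM, while compound 1 `Cc1c(OCC(=O)Nc2cccc(NC(=O)c3ccc(N(C)C)cc3)c2)ccc2c(=O)ccoc12` gives 4160 nM, a gap well beyond the scatter. Compound 3 `Nc1ccc(C(=O)Nc2cccc(NC(=O)COc3ccc4c(=O)ccoc4c3)c2)cc1` is not yet measured; it differs from compound 2 by 4-aminophenyl in place of methyl on a carbonyl carbon. With no directly comparable pair measured, the step is expected to be a moderate loss, in the direction of the weaker number shown by compound 1 at 4160 nM. Compound 3 is thus estimated at 600 nM, within 150 nM to 2500 nM, an expected step of a 4.4-fold higher number from compound 2 to compound 3 (0.64 log units; beyond the scatter).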

Compound 3, half-maximal inhibitory concentration: 83 nM
For compound 3 the middle estimate is 7.2-fold (0.86 log units) above the measured one; measured number below the stated range.
By their numbers in this assay, from the lowest: compounds 3 and 2 (each within the scatter of the next); then compound 1.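

At the amide end, on a carbonyl carbon whose other neighbour is the amide-type nitrogen, 4-aminophenyl in place of methyl gives a 1.6-fold lower number from compound 2 to compound 3 (0.21 log units; within the scatter) in this assay, so a group carrying an aromatic ring and a small methyl read alike here. Compound 1 differs from compound 2 in more than one place and could not show this position alone. Nothing on hand gives a reason for this result.

Open, on these data alone, is whether plain phenyl, without the amine, reads the same, and how a carboxylic acid or a longer alkyl chain on this carbonyl carbon would read.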